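Notes on compound 3: ethoxy in place of hydroxy

The source may report more compounds than this note shows. Statements on the series, on what has been measured and on what is new or still open speak of the compounds shown alone.

Two compounds have so far been measured in a functional assay on TSU-Pr1 cells (Homo sapiens) for antiproliferative activity, read by sulforhodamine B assay; on this read-out higher numbers stand for weaker inhibition and lower numbers for stronger inhibition:

compound 1, `CCCCCCCCCCCCCCCCCCNC(=O)[C@@H]1CSC(c2cccc(O)c2)N1`: 4000 nM
compound 2, `CCCCCCCCCCCCCCCCCCNC(=O)[C@@H]1CSC(c2ccc(O)cc2)N1`: 3000 nM

Among the compounds with values here, compound 2 holds the lowest of the two numbers in this assay, but its only neighbour is compound 1, and the step of a 1.3-fold lower number from compound 1 to compound 2 (0.12 log units; within the scatter) is within the scatter, so no order between the two can be claimed. The next compound, compound 3 `CCCCCCCCCCCCCCCCCCNC(=O)[C@@H]1CSC(c2ccc(OCC)cc2)N1`, has not yet been measured. It differs from compound 2 by ethyl in place of hydrogen on an oxygen on an aromatic ring. No measured step bears on this change: the single step shown, from compound 1 to compound 2, moves the hydroxy to another place on the ring and keeps it as a hydroxy, and that step is within the scatter. The set contains nothing that tells what capping the hydroxy with ethyl does in this assay. In the absence of any bearing step, compound 3 is expected to give a number close to compound 2, with the step of no change at the digits printed from compound 2 to compound 3 (within the scatter) not beyond the scatter, and the range is kept wide to cover either direction. The estimate for compound 3 is 3000 nM, between 1000 nM and 10000 nM.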

Compound 3, half-maximal inhibitory concentration: > 20000 nM
Compound 3: no number, only a limit; the forecaster's own chance of this, stated with the estimate: 5%; middle value at least 6.6-fold (0.82 log units) from the limit.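

The value of compound 3 in this assay is a limit of the assay and not a number: the limit of > 20000 nM in this assay, at which 1 of the 3 values shown sits.

Even read as a limit, placing ethyl on the oxygen of the 4-hydroxyphenyl group gives an at least 6.6-fold higher number from compound 2 to compound 3 (0.82 log units; beyond the scatter), so this is the first change in the series that moves the read-out beyond the scatter, towards weaker inhibition, whereas moving the hydroxy around the ring gave only a 1.3-fold lower number from compound 1 to compound 2 (0.12 log units; within the scatter). The comparison with the 3-hydroxyphenyl compound points the same way, with an at least 5.0-fold higher number from compound 1 to compound 3 (0.69 log units; beyond the scatter), so the free hydroxy, in either ring place shown, goes with stronger inhibition than the 4-ethoxyphenyl group in these three compounds.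

The compounds shown do not separate the effect of capping the oxygen as such from the effect of the size of the cap, and methoxy, acetoxy or an amine at the same place would bear on that question. They also leave open whether ethoxy on the other ring place behaves the same way, and whether the result holds with a shorter alkyl chain on the amide.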